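This account rests on a few compounds, and the source may have more. Where it says the series, first, only, none or still open, it means among the compounds named here.

Compounds measured in an assay on isolated protein for inhibition of Equilibrative nucleoside transporter 1 (Homo sapiens); a higher number here means a weaker inhibitor, a lower number a stronger inhibitor:

Compound 1 `OC[C@H]1O[C@@H](n2cnc3c(SCc4cccc(Cl)c4)ncnc32)[C@H](O)[C@@H]1O` gives 18.2 nM
Compound 2 `Cc1ccc(CSc2ncnc3c2ncn3[C@@H]2O[C@H](CO)[C@@H](O)[C@H]2O)cc1` gives 15.1 nM

Both measured compounds share one core and differ only in the group carried on the chain carbon bound to the sulfur. The step of a 1.2-fold lower number from compound 1 to compound 2 (0.08 log units; within the scatter) is within the scatter, so compound 2 and compound 1 cannot be told apart in this assay; compound 2 simply stands beside compound 1.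

Compound 3 `CC(C)(C)c1ccc(CSc2ncnc3c2ncn3[C@@H]2O[C@H](CO)[C@@H](O)[C@H]2O)cc1` is not yet measured. It differs from compound 2 by tert-butyl in place of methyl on an aromatic carbon. Going by the values given here, no measured step swaps one group for a larger one at that position; the only step in hand, from compound 1 to compound 2, exchanged a different substitution pattern on the same ring and left the number essentially unchanged. On that basis little movement beyond the scatter is expected, with a slight lean toward a higher number. The step from compound 2 to compound 3 in this assay is expected to be a 2.0-fold higher number from compound 2 to compound 3 (0.30 log units; within the scatter). Compound 3 is estimated at 30 nM, within 10 nM to 100 nM.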

Compound 3, inhibition constant: 10000 nM
Compound 3: the middle estimate sits 330-fold (2.52 log units) below what was measured, and the stated range ends below it.
By their numbers in this assay, from the lowest: compounds 2 and 1 (each within the scatter of the next); then compound 3.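

In this assay, the earlier pair left the impression that this ring accepts changes with little effect, but the aromatic carbon para to a large group proves highly sensitive to what it carries. Tert-butyl in place of methyl there gives a 660-fold higher number from compound 2 to compound 3 (2.82 log units; beyond the scatter), a large loss from a change confined to one group. The comparison with the other earlier compound agrees, with 4-(tert-butyl)phenyl in place of 3-chlorophenyl giving a 550-fold higher number from compound 1 to compound 3 (2.74 log units; beyond the scatter), and nothing available explains why this group costs so much.

Still open, on these data alone, is how an ethyl or isopropyl group would read at this carbon, and so whether the number climbs gradually or abruptly as the group grows. Also open, as far as these compounds go, is whether a methoxy or trifluoromethyl group here would stay close to methyl or move toward tert-butyl.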